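Trimethoxyphenyl Replaces Chlorophenyl on a Triazole Dithiocarbamate

The compounds below may be only part of what the source reports. "The series", "measured", "known", "first", "only" and "open" are said of these compounds alone.

Measured compounds:
Compound 2 `COc1ccc(Cn2cc(CSC(=S)N3CCN(C(=O)OCc4ccccc4)CC3)nn2)cc1`: 30500 nM
Compound 3 `O=C(OCc1ccccc1)N1CCN(C(=S)SCc2cn(Cc3ccccc3Cl)nn2)CC1`: 21400 nM
Compound 1 `COc1cc(Cn2cc(CSC(=S)N3CCNCC3)nn2)cc(OC)c1OC`: "not determined" (no result reported)

In a functional assay on MCF7 cells (Homo sapiens) for inhibition, read by MTT assay, with a stated time of 72 h (a lower number here means a stronger inhibitor, a higher number a weaker inhibitor), compound 3 gives 21400 nM, the lowest of the two numbers available, and compound 2 gives 30500 nM, with a 1.4-fold lower number from compound 2 to compound 3 (0.15 log units; within the scatter), so the two cannot be ordered. Compound 4 `COc1cc(Cn2cc(CSC(=S)N3CCN(C(=O)OCc4ccccc4)CC3)nn2)cc(OC)c1OC` differs from compound 3 by 3,4,5-trimethoxyphenyl in place of 2-chlorophenyl on a saturated chain carbon bound to an aromatic nitrogen. For the measured compounds named here, the only step that bears on this change is the earlier exchange of one substituted phenyl for another, a 1.4-fold lower number from compound 2 to compound 3 (0.15 log units; within the scatter), which stayed within the scatter. Compound 1 carries the same trimethoxyphenyl but no number was reported for it. For compound 4 the expected step is therefore a 1.1-fold higher number from compound 3 to compound 4 (0.05 log units; within the scatter), none beyond the scatter. Compound 4 is estimated at 24000 nM, in the range 9000 nM to 65000 nM.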

Compound 4, half-maximal inhibitory concentration: > 128000 nM
Compound 4: only a limit was reported; the forecaster's own chance of this, stated with the estimate: 10%; at least 5.3-fold (0.72 log units) between middle value and limit.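

The value of compound 4 is a limit and not a number: the limit of > 128000 nM in this assay, at which 1 of the 4 values shown sits. Even so, exchange of the aryl group on a saturated chain carbon bound to an aromatic nitrogen now registers, with 3,4,5-trimethoxyphenyl giving an at least 5.9-fold higher number from compound 3 to compound 4 (0.77 log units; beyond the scatter), and an at least 4.1-fold higher number from compound 2 to compound 4 (0.62 log units; beyond the scatter). This position is therefore not indifferent to the substituted phenyl, which a 1.4-fold lower number from compound 2 to compound 3 (0.15 log units; within the scatter) alone could not show.

The compounds shown leave open how far the true value of compound 4 lies beyond its limit. They also leave open whether an unsubstituted phenyl or a dimethoxyphenyl would behave like 2-chlorophenyl or like 3,4,5-trimethoxyphenyl.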